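A few compounds are considered here, and "the series" means these few. Any claim that something is new, unique, unknown or untested is made for them only; others in the source may bear on it.

Among the measured compounds shown here, in a physicochemical assay for solubility, measured as kinetic solubility, with a stated time of 15 h, at pH 7.4 (a higher number here means a more soluble compound, a lower number a less soluble compound), compound 1 `OC[C@H]1O[C@H](Oc2ccc(-c3ccc(Cl)cc3Cl)cc2Cl)[C@@H](O)[C@@H](O)[C@@H]1O` gives 8 ug/mL, while compound 2 `O=[N+]([O-])c1ccc(-c2ccc(O[C@H]3O[C@H](CO)[C@@H](O)[C@H](O)[C@@H]3O)c(Cl)c2)cc1` gives 117 ug/mL, the higher of the two numbers measured so far. Replacing the 2,4-dichlorophenyl with 4-nitrophenyl on an aromatic carbon gives a 15-fold higher number from compound 1 to compound 2 (1.17 log units; beyond the scatter), a large step beyond the scatter.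

Compound 3 `O=[N+]([O-])c1cccc(-c2ccc(O[C@H]3O[C@H](CO)[C@@H](O)[C@H](O)[C@@H]3O)c(Cl)c2)c1` keeps the rest of compound 2 and carries 3-nitrophenyl in place of 4-nitrophenyl on an aromatic carbon. The new group stands on the same aromatic carbon, meta to a chloro group and para to a large group.

For the measured compounds named here, only that one measured step bears on this change, and it exchanged different groups, so it offers no direct measure for two nitrophenyl isomers. The two compounds have the same atoms, joined differently, so a step far smaller than a 15-fold higher number from compound 1 to compound 2 (1.17 log units; beyond the scatter) is expected, with no direction beyond the scatter. The estimated change is a 1.1-fold higher number from compound 2 to compound 3 (0.03 log units; within the scatter). For compound 3, the expected value in this assay is 125 ug/mL, within an estimated range of 50 ug/mL to 300 ug/mL.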

Compound 3, solubility: 23 ug/mL
Compound 3: the middle estimate sits 5.4-fold (0.74 log units) above what was measured, outside the stated range (below it).
By their numbers in this assay, from the lowest: compound 1; then compound 3; then compound 2.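

The earlier step exchanged one substituent on this aromatic carbon for a quite different one, whereas 4-nitrophenyl and 3-nitrophenyl have the same atoms, joined differently, and this assay still separates them, with a 5.1-fold lower number from compound 2 to compound 3 (0.71 log units; beyond the scatter) in this exchange. At this place, then, the arrangement within the nitrophenyl group alone carries a step beyond the scatter, and matching counts of heavy atoms, donors and acceptors do not make the two groups interchangeable. Against 2,4-dichlorophenyl, 3-nitrophenyl still gives a 2.9-fold higher number from compound 1 to compound 3 (0.46 log units; beyond the scatter) on the same carbon, so both nitrophenyl compounds stand above compound 1, though nothing at hand explains why the two isomers part.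

The compounds shown leave open how a carboxylic acid, an amine or a nitrile on this phenyl ring would read in this assay alongside these numbers. They also leave open whether the gap between 3-nitrophenyl and 4-nitrophenyl would persist if the chloro group of the shared core gave way to fluorine.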